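The source may report more compounds than this note shows. Statements on the series, on what has been measured and on what is new or still open speak of the compounds shown alone.

Compound 3 `CC1CCCN1C(=O)CCSc1nc2cc(Cl)ccc2o1` belongs to a small set built on a shared core, alongside compound 1 `O=C(CCSc1nc2cc(F)ccc2o1)N1CCCC1` and compound 2 `O=C(CCSc1nc2cc(Cl)ccc2o1)NC1CCCC1`, the members differing in the group attached to the carbonyl carbon. In an ADME assay on microsomes from liver (Mus musculus) for metabolic stability, read by LC-MS, using NADPH, with a stated time of 45 min, tested at 0.5 uM (a higher number here means faster removal of the compound, a lower number slower removal), compound 1 gives 115 mL/min/g and compound 3 gives 98 mL/min/g; for compound 2 the outcome is "not determined" (no result reported). Among the measured compounds shown here, compound 3 therefore has one of only two numbers available, and its gap to compound 1 lies within the scatter of repeated measurements, so neither compound stands apart from the other. Compound 4 `CN1CCN(C(=O)CCSc2nc3cc(Cl)ccc3o2)CC1` is the next member and has not yet been measured in this assay. It differs from compound 3 in one place: 4-methylpiperazin-1-yl in place of 2-methylpyrrolidin-1-yl on a carbonyl carbon. For the measured compounds named here, no step between measured compounds exists to guide the size of this change, so there is no basis for expecting a move beyond the scatter in either direction. The expected step is accordingly small: a 1.2-fold lower number from compound 3 to compound 4 (0.06 log units; within the scatter). In this assay compound 4 is estimated to give 85 mL/min/g, with a range from 40 mL/min/g to 170 mL/min/g.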

Compound 4, intrinsic clearance in a liver preparation (reported as CLH), per the amount of preparation that the assay uses: 41.5 mL/min/g
For compound 4 the middle estimate is 2.0-fold (0.31 log units) above the measured one, within the range that was stated.
By their numbers in this assay, from the lowest: compound 4; then compounds 3 and 1 (each within the scatter of the next).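

In this assay, among the compounds shown here, placing 4-methylpiperazin-1-yl instead of 2-methylpyrrolidin-1-yl on the carbonyl carbon gives a 2.4-fold lower number from compound 3 to compound 4 (0.37 log units; beyond the scatter), the only step in this set and one that lies beyond the scatter. It shows that, with the rest of the structure unchanged, exchanging this group alone can move the read-out by more than repeated measurements would. Nothing shown here accounts for the size or direction of this step.

The compounds shown do not separate the larger ring from its second nitrogen or from the methyl on that nitrogen; piperidin-1-yl, morpholin-4-yl and unsubstituted piperazin-1-yl on the same carbonyl carbon would bear on this. As far as these compounds go, it also remains open whether the same exchange has a comparable effect on the fluorine-bearing core of compound 1.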